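Cyano in Place of Dimethylamino: Where Compound 3 Might Land

The compounds below may be only part of what the source reports. "The series", "measured", "known", "first", "only" and "open" are said of these compounds alone.

Compound 1 `CC(C)(C)c1ccc(NC(=O)c2csc(Cc3c(Cl)cccc3Cl)n2)cc1` gives 570 nM in an assay on CHO cells, read by calcium flux; on this read-out higher numbers stand for weaker inhibition and lower numbers for stronger inhibition. Compound 2 `CN(C)c1ccc(NC(=O)c2csc(Cc3c(Cl)cccc3Cl)n2)cc1` carries dimethylamino in place of tert-butyl on an aromatic carbon. In this assay compound 2 reaches only the limit > 4000 nM, so compound 2 stands at the weak end of the two numbers shown. For the measured compounds named here, the only measured step is an at least 7.0-fold higher number from compound 1 to compound 2 (0.84 log units; beyond the scatter). Compound 3 `N#Cc1ccc(NC(=O)c2csc(Cc3c(Cl)cccc3Cl)n2)cc1` differs from compound 2 by cyano in place of dimethylamino on an aromatic carbon. Going by the values given here, no measured step involves cyano, so that one step gives little guidance on direction. Compound 3 is therefore expected near 2500 nM, between 500 nM and 8000 nM. The expected step is an at least 1.6-fold lower number from compound 2 to compound 3 (0.20 log units; that floor lies within the scatter).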

Compound 3, half-maximal inhibitory concentration: 450 nM
For compound 3 the middle estimate is 5.6-fold (0.74 log units) above the measured one; the whole stated range lies above it.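

Cyano in place of dimethylamino gives an at least 8.8-fold lower number from compound 2 to compound 3 (0.94 log units; beyond the scatter) in this assay, while cyano in place of tert-butyl gives a 1.3-fold lower number from compound 1 to compound 3 (0.10 log units; within the scatter), so compound 1 and compound 3 cannot be told apart here. At this position, para to a large group, replacing tert-butyl therefore need not cost activity, and among these three groups only dimethylamino stands apart. Compound 2 stands only as a limit of the assay: the limit of > 4000 nM in this assay, at which 1 of the 3 values shown sits.

As far as these compounds go, it remains open whether a primary amine, a methoxy group or a carboxylic acid at this position would track dimethylamino or cyano. From the compounds shown here alone, how far a longer chain would be tolerated also stays open.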